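This account rests on a few compounds, and the source may have more. Where it says the series, first, only, none or still open, it means among the compounds named here.

The series is followed in a functional assay on the whole organism for inhibition, with Cavia porcellus as the target, with a stated time of 2 h; on this read-out higher numbers stand for an effect only at larger amounts of compound and lower numbers for an effect already at smaller amounts. Compound 1 `COc1ccc(C(=C/C=C/C(=O)NCCCCc2cccnc2)c2ccc(OC)c(OC)c2)cc1OC` gives 27 mg/kg in this assay. Compound 3 `COc1ccc(C(=C/C=C/C(=O)N[C@H](C)CCCc2cccnc2)c2ccc(OC)c(OC)c2)cc1OC` differs from compound 1 by methyl in place of hydrogen on a saturated chain carbon bound to an amide-type nitrogen and a saturated chain carbon. In this assay compound 3 gives 26 mg/kg, and the step of a 1.0-fold lower number from compound 1 to compound 3 (0.02 log units; within the scatter) lies within the scatter, so the two values are read as the same. Compound 2 `COc1cccc(C(=C/C=C/C(=O)NCCCCc2cccnc2)c2cccc(OC)c2)c1` is built on a different core; the difference between the two cores is not broken down here. In this assay compound 2 gives 80 mg/kg, the highest number of the three and beyond the scatter from both compound 1 and compound 3. Compound 4 `COc1cccc(C(=C/C=C/C(=O)N[C@H](C)CCCc2cccnc2)c2cccc(OC)c2)c1` is not yet measured and stands to compound 2 as compound 3 stands to compound 1: the change is methyl in place of hydrogen on a saturated chain carbon bound to an amide-type nitrogen and a saturated chain carbon, at the same place in both pairs, so it is the same change. The step from compound 2 to compound 4 in this assay is expected to be no change at the digits printed from compound 2 to compound 4 (within the scatter), as flat as the earlier one, because a 1.0-fold lower number from compound 1 to compound 3 (0.02 log units; within the scatter) left the number unchanged on the other core. For compound 4 the expected value in this assay is 80 mg/kg, with a range from 45 mg/kg to 140 mg/kg.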

Compound 4, dose for 50% inhibition: 29 mg/kg
For compound 4 the middle estimate is 2.8-fold (0.44 log units) above the measured one, and the stated range ends above it.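

In this assay methyl in place of hydrogen on the saturated chain carbon bound to the amide-type nitrogen brings a 2.8-fold lower number from compound 2 to compound 4 (0.44 log units; beyond the scatter), whereas on the core of compound 1 the same change brought a 1.0-fold lower number from compound 1 to compound 3 (0.02 log units; within the scatter). Set side by side, the two steps cannot be told apart: the same change on two cores in this assay, a 1.0-fold lower number (0.02 log units; within the scatter) from compound 1 to compound 3 and a 2.8-fold lower number (0.44 log units; beyond the scatter) from compound 2 to compound 4, 2.7-fold (0.42 log units) apart, within the scatter of two such steps The change can therefore be carried between these two cores with no rise in the number on either, but these two pairs do not show that the step is the same size on both cores, that it depends on the core, or that it would hold on any other core.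

The compounds shown leave open what an ethyl group on the same saturated chain carbon would do, and how a chain longer than the 4-(pyridin-3-yl)butyl chain would read on either core. The opposite configuration at the methyl-bearing carbon also stays open, as only one configuration appears among these compounds.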